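A few compounds are considered here, and "the series" means these few. Any claim that something is new, unique, unknown or untested is made for them only; others in the source may bear on it.

Measured so far in an assay on HeLa cells for inhibition of sphingosine-1-phosphate transporter SPNS2 (Mus musculus), read by LC-MS, tested at 2 uM; a lower number here means less inhibition, a higher number more inhibition at the concentration tested (going by the name of the read-out):
Compound 1 `CCCCCCCCCCc1ccc(-c2noc(CCCCN)n2)cc1` gives 55%.
Compound 2 `CCCCCCCCCCc1ccc(-c2noc(CCCN(C)C)n2)cc1` gives 8%.
Compound 3 `CCCCCCCCCCc1ccc(-c2noc([C@@H]3CC[C@H](N)C3)n2)cc1` gives 38%.

Compound 1 stands highest of the three numbers. Its nearest neighbour is compound 3 and its furthest is compound 2, and both steps away from compound 1 are beyond the scatter.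

Compound 4 `CCCCCCCCCCc1ccc(-c2noc([C@H]3CCC[C@@H](N)C3)n2)cc1` has not yet been measured. It differs from compound 1 in one place: 3-aminocyclohexyl in place of 4-aminobutyl on an aromatic carbon.

The measured step that bears most directly on this change is the one that also closes the chain into a ring, a number 17 percentage points lower from compound 1 to compound 3 (beyond the scatter), a modest drop. The step of a number 47 percentage points lower from compound 1 to compound 2 (beyond the scatter) concerns a different kind of change, yet it shows that alterations at this end of compound 1 can move the read-out a great deal. The step of a number 30 percentage points higher from compound 2 to compound 3 (beyond the scatter) places the 3-aminocyclopentyl compound well above the 3-(dimethylamino)propyl compound. Going from 4-aminobutyl to 3-aminocyclohexyl is expected to resemble the move to 3-aminocyclopentyl, so a modest step down from compound 1 is expected, a number 15 percentage points lower from compound 1 to compound 4 (beyond the scatter), though the scatter leaves room for no change at all.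

Compound 4 is therefore estimated at 40%, with a range from 22% to 58%.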

Compound 4, a percentage reported as inhibition, at one concentration (the size of the read-out at that concentration, not a potency): 29%
Beside the measured number, compound 4's estimate is 11 percentage points above it; low and high end bracket the measured number.
By their numbers in this assay, from the lowest: compound 2; then compounds 4 and 3 (each within the scatter of the next); then compound 1.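

In this assay, a second ring-closed amine also falls short of the open chain, a number 26 percentage points lower from compound 1 to compound 4 (beyond the scatter), so compound 3 is no longer the only case: both compounds with a ring of carbon only carrying the amine stand beyond the scatter below 4-aminobutyl. Ring size does not separate the two, with a number 9 percentage points lower from compound 3 to compound 4 (within the scatter), while the 3-aminocyclohexyl group still stands clear of 3-(dimethylamino)propyl, with a number 21 percentage points higher from compound 2 to compound 4 (beyond the scatter). Nothing available on these compounds accounts for the cost of closing the ring.

Open is whether the defined stereocentres of the 3-aminocyclohexyl group matter, since the compounds shown give one stereoisomer for each ring and so cannot separate ring size from the arrangement of the amine. Also open, as far as these compounds go, is how a piperidine ring, with the nitrogen inside the ring, or a longer chain such as 5-aminopentyl would compare with 4-aminobutyl, and whether a single methyl on the amine would fall closer to compound 1 or to compound 2.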